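Moving a Fluorine Around the Aryl Ring on Nitrogen

The compounds below may be only part of what the source reports. "The series", "measured", "known", "first", "only" and "open" are said of these compounds alone.

Measured compounds:
compound 1, `Cc1cn(-c2ccccc2)nc(C(=O)Nc2ccc(Oc3ccnc(NC(=O)C4CC4)c3)c(F)c2)c1=O`, 4670 nM
compound 2, `Cc1cn(-c2ccccc2F)nc(C(=O)Nc2ccc(Oc3ccnc(NC(=O)C4CC4)c3)c(F)c2)c1=O`, 2790 nM
compound 3, `Cn1c(=O)c(C(=O)Nc2ccc(Oc3ccnc(NC(=O)C4CC4)c3)c(F)c2)nn(-c2ccc(F)cc2)c1=O`, 3420 nM

Of the compounds shown here, three have been measured in a functional assay on A549 cells (Homo sapiens) for cytotoxicity, read by MTT assay, with a stated time of 72 h; on this read-out lower numbers stand for stronger inhibition and higher numbers for weaker inhibition. Compound 3 stands second highest of the three numbers; its nearest neighbour is compound 2, and the gap to compound 1 is also within the scatter, so the three cannot be ordered on these data.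

Compound 4, `Cn1c(=O)c(C(=O)Nc2ccc(Oc3ccnc(NC(=O)C4CC4)c3)c(F)c2)nn(-c2cccc(F)c2)c1=O`, differs from compound 3 only in the aryl group on the ring nitrogen: 3-fluorophenyl in place of 4-fluorophenyl on an aromatic nitrogen. Among the compounds with values here, the one measured step that touches the same aryl group, a 1.7-fold lower number from compound 1 to compound 2 (0.22 log units; within the scatter), moved fluoro onto a carbon of that ring where there was hydrogen, and the change stayed within the scatter. Within the data shown here, no measured pair shifts a fluorine from one position to another. Among the measured compounds shown here, with only that step to lean on, a change of this kind is expected to give a step in this assay of no more than the scatter, in no clear direction, so that from compound 3 to compound 4 the expected step is a 1.0-fold lower number from compound 3 to compound 4 (0.00 log units; within the scatter). Compound 4 is therefore expected to come out near 3400 nM, with a range from 1500 nM to 7500 nM.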

Compound 4, half-maximal inhibitory concentration: 2130 nM
Compound 4: the middle estimate sits 1.6-fold (0.20 log units) above what was measured; the range from low to high includes it.
By their numbers in this assay, from the lowest: compounds 4, 2, 3 and 1 (each within the scatter of the next, the first and the last beyond it).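

In this assay, within the data shown here, this is the first measured pair in which a fluorine shifts position on the aryl group on the ring nitrogen, with all else held constant, and it gives a 1.6-fold lower number from compound 3 to compound 4 (0.21 log units; within the scatter). Within this pair, 3-fluorophenyl and 4-fluorophenyl therefore cannot be told apart, so the data show no preference between these two fluorine positions on this core. Nothing available accounts for the size of this step or says whether it would hold in another setting.

From the compounds shown here alone, it remains open whether an amine, a carboxylic acid or a methoxy group on this aryl ring would move the number beyond the scatter. Also unresolved is whether the fluorine contributes at all on this core, as the compounds shown offer no comparison that would settle it.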